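The source may hold more compounds than are shown below. What is called first, only, known or untested is meant among the compounds shown, and "the series" means these compounds.

Measured so far:
Compound 1 `Cc1ccc(/C=C2\CC[C@H]3C(C)(C)CCC[C@]3(C)[C@H]2CCC(C)CC(=O)O)cc1` gives 91000 nM in a functional assay on THP-1 cells (Homo sapiens) for cytotoxicity, read by MTT assay, with a stated time of 72 h; a higher number here means a weaker inhibitor, a lower number a stronger inhibitor.
Compound 2 `CC(CC[C@H]1/C(=C/c2ccc([N+](=O)[O-])cc2)CC[C@H]2C(C)(C)CCC[C@]12C)CC(=O)O` gives 68000 nM in this assay.
Compound 3 `CC(CC[C@H]1/C(=C/c2ccc(Br)cc2)CC[C@H]2C(C)(C)CCC[C@]12C)CC(=O)O` reaches only a limit of the assay, > 200000 nM, in this assay.

Compound 3 thus stands as the weakest of the three, with a limit and no number, since the step of an at least 2.1-fold higher number from compound 1 to compound 3 (0.34 log units; beyond the scatter) and the step of an at least 2.9-fold higher number from compound 2 to compound 3 (0.46 log units; beyond the scatter) both end at the limit of > 200000 nM in this assay, at which 1 of the 3 values shown sits. Compound 4 `CC(CC[C@H]1/C(=C/c2ccc(I)cc2)CC[C@H]2C(C)(C)CCC[C@]12C)CC(=O)O` differs from compound 3 in one place: iodo in place of bromo on an aromatic carbon. Within the data shown here, no measured step exchanges one halogen for another, and the only steps touching this position run into the limit, so no direction can be read from them. The expectation is that compound 4 stays near that limit, with a step of a number no higher from compound 3 to compound 4 (the limit leaves the size open) expected to remain within the scatter. Compound 4 is estimated at 200000 nM, within 90000 nM to 400000 nM.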

Compound 4, half-maximal inhibitory concentration: 33000 nM
Beside the measured number, compound 4's estimate is 6.1-fold (0.78 log units) above it, outside the stated range (below it).
By their numbers in this assay, from the lowest: compound 4; then compounds 2 and 1 (each within the scatter of the next). At a limit, above all of these: compound 3.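

In this assay, the halogen at this position proves to count, for the exchange of one halogen for another gives a clear drop in the number (an at least 6.0-fold lower number from compound 3 to compound 4 (0.78 log units; beyond the scatter)). Iodo also separates from the two non-halogen groups (a 2.1-fold lower number from compound 2 to compound 4 (0.31 log units; beyond the scatter); a 2.8-fold lower number from compound 1 to compound 4 (0.44 log units; beyond the scatter)), so the group here can shift the number in either direction from methyl and nitro. As far as these compounds go, the full size of the halogen exchange stays open because compound 3 stands at a limit: the limit of > 200000 nM in this assay, at which 1 of the 4 values shown sits.

From the compounds shown here alone, what chloro, fluoro or an amine in this place would give remains open. So does whether iodo keeps its lead when the carboxylic acid chain changes.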